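Swapping a Pyridyl for a Chlorophenyl: Expected Cytotoxicity

A few compounds are considered here, and "the series" means these few. Any claim that something is new, unique, unknown or untested is made for them only; others in the source may bear on it.

Compound 1 `O=C1Oc2ccccc2N/C1=C\C(=O)c1ccncc1` was tested in an ADME assay on Vero cells (Chlorocebus sabaeus) for cytotoxicity, read by MTT assay, with a stated time of 72 h; on this read-out lower numbers stand for higher toxicity in this test and higher numbers for lower toxicity in this test. Compound 1 reaches only the limit of this assay, > 1870000 nM, so its result is a boundary rather than a number. Among the measured compounds shown here, a second compound of a different build, compound 2 `O=C(NNC(=O)c1ccncc1)C(=O)Nc1ccc(Cl)cc1O`, gives in this assay 1170000 nM; no step between compound 2 and compound 1 is counted, and the two values show only that both lie high on the scale. Among the measured values, (the limit of > 1870000 nM in this assay, at which 1 of the 2 values shown sits), which is where compound 1 stands.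

Compound 3 `O=C1Oc2ccccc2N/C1=C\C(=O)c1ccccc1Cl` has not yet been measured. It differs from compound 1 in one place: 2-chlorophenyl in place of pyridin-4-yl on a carbonyl carbon. For the measured compounds named here, no measured pair shows this kind of change, so there is no measured step to lean on. The expected step is an at least 1.2-fold lower number from compound 1 to compound 3 (0.09 log units; that floor lies within the scatter), not beyond the usual scatter. For compound 3 the estimated value in this assay is 1500000 nM, with a range from 500000 nM to 3000000 nM.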

Compound 3, half-maximal cytotoxic concentration: 1570000 nM
The estimate for compound 3 lay 1.0-fold (0.02 log units) below the measured number, and the stated range covers the measured number.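

At this carbonyl carbon, 2-chlorophenyl can take the place of pyridin-4-yl while the reading in this assay stays high on the scale, with an at least 1.1-fold lower number from compound 1 to compound 3 (0.07 log units; that floor lies within the scatter). Unlike compound 1, compound 3 gives a true number, 1570000 nM, so the shared core now has a measured value against which further changes can be set. The step is only a floor, and its real size cannot be read, because the result for compound 1 is a limit and not a number: the limit of > 1870000 nM in this assay, at which 1 of the 3 values shown sits.

A plain phenyl on this carbonyl carbon would help to separate the part played by the chlorine from the part played by the ring nitrogen. As far as these compounds go, how an amine or a carboxylic acid at this place would read also remains open.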